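This account rests on a few compounds, and the source may have more. Where it says the series, first, only, none or still open, it means among the compounds named here.

Compound 1 `C=CCn1c(=O)n(C2C=CC(CO)O2)c2nc(N)nc(O)c21` holds the highest number of the three compounds measured here. In a functional assay on YAC-1 cells (Mus musculus) (a lower number here means a smaller maximal response, a higher number a larger maximal response), compound 1 gives 89%, while compound 2 `C=CCn1c(=O)n(C2OC(CO[Si](c3ccccc3)(c3ccccc3)C(C)(C)C)[C@@H](O)[C@H]2O)c2nc(N)nc(O)c21` gives 15% and compound 3 `C=CCn1c(=O)n([C@H]2CO[C@@H](CO)C2)c2nc(N)nc(O)c21` gives 0%. Among the compounds with values here, the only single-place step measured, a number 89 percentage points lower from compound 1 to compound 3 (beyond the scatter), concerns a different part of the molecule and so says nothing about the change followed here. Compound 4 `CCCn1c(=O)n(C2C=CC(CO)O2)c2nc(N)nc(O)c21` differs from compound 1 by ethyl in place of vinyl on a saturated chain carbon bound to an aromatic nitrogen. Within the data shown here, no measured step touches this chain, so the expectation rests only on the small size of the change: a step of modest size is expected, a number 14 percentage points lower from compound 1 to compound 4 (beyond the scatter), most likely downward and possibly within the scatter. Compound 4 is therefore estimated at 75%, in a range from 40% to 95%.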

Compound 4, largest response reached (reported as maximal response), in percent of the reference or control that the assay uses: 102%
The estimate for compound 4 lay 27 percentage points below the measured number, outside the stated range (above it).
By their numbers in this assay, from the lowest: compound 3; then compound 2; then compound 1; then compound 4.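

Changing allyl to propyl, that is, ethyl in place of vinyl on a saturated chain carbon bound to an aromatic nitrogen, gives a number 13 percentage points higher from compound 1 to compound 4 (beyond the scatter) in this assay. Within the data shown here, this is the first measured step at this chain, and it shows that the double bond is not needed to keep the response high in this pair. No measurement shown gives a reason for the rise. On these data alone, whether a longer chain such as butyl, or a chain ending in an amine or a carboxylic acid, would raise or lower the response remains open. So does whether the same change would have a similar effect on the core of compound 3.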